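Working notes: sulfamoylamino for methoxy, compound 4

The source may hold more compounds than are shown below. What is called first, only, known or untested is meant among the compounds shown, and "the series" means these compounds.

Numbers so far come from a functional assay on MDA-MB-231 cells (Homo sapiens) for antiproliferative activity, read by MTT assay, with a stated time of 72 h; on this read-out higher numbers stand for weaker inhibition and lower numbers for stronger inhibition:
compound 1 `Cc1ccc(NC(=O)Nc2cccc(-c3nc(-c4ccc(NC(=O)c5cccnc5)cc4Cl)no3)c2)cc1` gives 3500 nM
compound 2 `COc1cccc(NC(=O)Nc2cccc(-c3nc(-c4ccc(NC(=O)c5cccnc5)cc4Cl)no3)c2)c1` gives 6700 nM
compound 3 `COc1ccc(NC(=O)Nc2cccc(-c3nc(-c4ccc(NC(=O)c5cccnc5)cc4Cl)no3)c2)cc1` gives 3000 nM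

Compound 3 holds the lowest of the three numbers: a 2.2-fold lower number from compound 2 to compound 3 (0.35 log units; beyond the scatter) is beyond the scatter, whereas a 1.2-fold lower number from compound 1 to compound 3 (0.07 log units; within the scatter) is within it, so compound 3 and compound 1 cannot be ordered.

Compound 4 `NS(=O)(=O)Nc1ccc(NC(=O)Nc2cccc(-c3nc(-c4ccc(NC(=O)c5cccnc5)cc4Cl)no3)c2)cc1` differs from compound 3 by sulfamoylamino in place of methoxy on an aromatic carbon. Among the measured compounds shown here, the only step at this same position, a 1.2-fold lower number from compound 1 to compound 3 (0.07 log units; within the scatter), was within the scatter; moving the group across the ring, a 1.9-fold higher number from compound 1 to compound 2 (0.28 log units; within the scatter) and a 2.2-fold lower number from compound 2 to compound 3 (0.35 log units; beyond the scatter), gave at most a modest shift. For the measured compounds named here, no measured step introduces a sulfamoylamino, so the guidance is thin. Compound 4 is therefore expected to stay near compound 3, with a 1.2-fold higher number from compound 3 to compound 4 (0.07 log units; within the scatter) as the estimated step. The estimate for compound 4 in this assay is 3500 nM, range 1200 nM to 10000 nM.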

Compound 4, half-maximal inhibitory concentration: 8900 nM
For compound 4 the middle estimate is 2.5-fold (0.41 log units) below the measured one; the measured number falls inside the stated range.
By their numbers in this assay, from the lowest: compounds 3, 1, 2 and 4 (each within the scatter of the next, the first and the last beyond it).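

Unlike methyl and methoxy, which cannot be ordered here, sulfamoylamino at this position gives a modest change beyond the scatter in this assay: a 3.0-fold higher number from compound 3 to compound 4 (0.47 log units; beyond the scatter) and a 2.5-fold higher number from compound 1 to compound 4 (0.41 log units; beyond the scatter). The change does not separate it from the group moved around the ring, since a 1.3-fold higher number from compound 2 to compound 4 (0.12 log units; within the scatter) stays within the scatter. No evidence on the cause of these steps is available.

Open, as far as these compounds go, is whether a simple amine or a methanesulfonamide at this position would behave like methoxy or like sulfamoylamino. Also open, from the compounds shown here alone, is whether sulfamoylamino would give the same result in the 3-substituted phenyl.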